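The source may hold more compounds than are shown below. What is called first, only, known or untested is meant among the compounds shown, and "the series" means these compounds.

Working notes on the series. Three compounds have a number in a functional assay on MDA-MB-231 cells for antagonist activity at C-X-C chemokine receptor type 4 (Homo sapiens), tested at 10 nM; on this read-out higher numbers stand for a stronger effect at the one concentration tested and lower numbers for a weaker effect. Compound 1 `Fc1cnc(NCc2ccc(CNc3nccc(C(F)(F)F)n3)cc2)nc1` gives 73%, compound 2 `c1cnc(NCc2ccc(CNc3ccccc3N3CCCC3)cc2)nc1` gives 61%, and compound 3 `COc1nccc(NCc2ccc(CNc3ccnc(OC)n3)cc2)n1` gives 24%. Compound 2 stands second highest of the three: compound 1 is higher by a margin beyond the scatter, compound 3 is lower by a wider margin, also beyond the scatter.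

Compound 4 `c1ccc(NCc2ccc(CNc3ncccn3)cc2)cc1` differs from compound 2 in one place: hydrogen in place of pyrrolidin-1-yl on an aromatic carbon. For the measured compounds named here, no measured pair isolates this change, so its size is open. Compound 2, which carries the pyrrolidin-1-yl, sits near the top of the set, and losing that group is expected to cost activity beyond the scatter. Compound 4 is therefore estimated at 40%, range 20% to 60%, a step of a number 21 percentage points lower from compound 2 to compound 4 (beyond the scatter) expected in this assay.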

Compound 4, a percentage reported as inhibition, at one concentration (the size of the read-out at that concentration, not a potency): 55%
Estimate against measurement, compound 4: 15 percentage points below; measured number inside the range.
By their numbers in this assay, from the lowest: compound 3; then compounds 4 and 2 (each within the scatter of the next); then compound 1.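

Hydrogen in place of pyrrolidin-1-yl on an aromatic carbon gives a number 6 percentage points lower from compound 2 to compound 4 (within the scatter) in this assay and is the first change in the series seen in isolation. At this position, ortho to a large group, the read-out at the one concentration tested therefore does not depend on the pyrrolidin-1-yl. No measurement at hand bears on the reason for this result.

As far as these compounds go, whether a carboxylic acid or a morpholin-4-yl on the same aromatic carbon would shift the number beyond the scatter remains open. From the compounds shown here alone, whether this pair would also read alike at other concentrations remains open too.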